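A few compounds are considered here, and "the series" means these few. Any claim that something is new, unique, unknown or untested is made for them only; others in the source may bear on it.

Compound 1 `Cc1cc(C)cc(NC(=O)NCCNS(=O)(=O)c2ccc(-c3ccccc3Oc3ccc([N+](=O)[O-])c([N+](=O)[O-])c3)s2)c1`: > 50000 nM
Compound 2 `COc1cccc(NC(=O)NCCNS(=O)(=O)c2ccc(-c3ccccc3Oc3ccc([N+](=O)[O-])c([N+](=O)[O-])c3)s2)c1`: 17800 nM

Both compounds were tested in an ADME assay on HEK-293T cells (Homo sapiens) for cytotoxicity, read by CCK-8 assay, with a stated time of 48 h; a higher number here means a weaker inhibitor, a lower number a stronger inhibitor. Among the compounds with values here, compound 2, at 17800 nM, holds the only exact number so far. The entry for compound 1 is a limit of the assay, not a number.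

Compound 3 `O=C(NCCNS(=O)(=O)c1ccc(-c2ccccc2Oc2ccc([N+](=O)[O-])c([N+](=O)[O-])c2)s1)Nc1ccc(Cl)cc1` keeps the shared core and alters only the aromatic group on the urea: 4-chlorophenyl in place of 3-methoxyphenyl on an amide-type nitrogen. Within the data shown here, the one measured step, an at least 2.8-fold lower number from compound 1 to compound 2 (0.44 log units; beyond the scatter), changed this same group and went beyond the scatter. From the compounds shown here alone, its true size stays open, since one end of it is a limit. It shows that this group can matter, but a single step cannot give a direction for a different group. The expected change is therefore small, a 1.1-fold lower number from compound 2 to compound 3 (0.05 log units; within the scatter), with a wide margin either way. For compound 3 the estimated value is 16000 nM, with an expected range of 6000 nM to 45000 nM.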

Compound 3, half-maximal inhibitory concentration: > 20000 nM
Compound 3: only a limit was reported; the forecaster's own chance of this, stated with the estimate: 20%; at least 1.2-fold (0.09 log units) between middle value and limit.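

Placing 4-chlorophenyl in place of 3-methoxyphenyl on an amide-type nitrogen gives no sign of a lower number in this assay, but the step is only a floor: an at least 1.1-fold higher number from compound 2 to compound 3 (0.05 log units; that floor lies within the scatter). The step between compound 1 and compound 3 cannot be read, as both of its ends are limits. Compound 3 therefore has a limit and not a number, and compound 2 still holds the only exact value: the limit of > 20000 nM in this assay, at which 1 of the 3 values shown sits.

From the compounds shown here alone, how far the true value of compound 3 lies from its limit stays open, so the real size of this step is unknown. Also open, going by these compounds, is how the number would respond to an amine or a carboxylic acid on the phenyl ring at this position, or to a longer chain in place of the ring.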